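Acetamido to Nitro on the Cyclohexyl Core

The source may report more compounds than this note shows. Statements on the series, on what has been measured and on what is new or still open speak of the compounds shown alone.

In an ADME assay on BHK cells (Mesocricetus auratus) for cytotoxicity, read by MTT assay, with a stated time of 96 h (a lower number here means that less compound is tolerated, a higher number that more compound is tolerated), three compounds have been tested. Compound 1 `Cn1c(-c2ccc([N+](=O)[O-])cc2)nc2cc(C(F)(F)F)ccc21` gives > 100000 nM, which is a limit of the assay rather than a number. Compound 2 `CC(=O)Nc1ccc(-c2nc3cc(C(F)(F)F)ccc3n2C)cc1` gives > 100000 nM, likewise a limit. Going by the values given here, compound 3 `CC(=O)Nc1ccc(-c2nc3cc(C(F)(F)F)ccc3n2C2CCCCC2)cc1` gives 15000 nM, the only plain number so far. The change cyclohexyl in place of methyl on an aromatic nitrogen produced an at least 6.6-fold lower number from compound 2 to compound 3 (0.82 log units; beyond the scatter). The change nitro in place of acetamido on an aromatic carbon produced a step that the two limits leave unreadable from compound 2 to compound 1, because the limit of > 100000 nM in this assay, at which 2 of the 3 values shown sit, is where both values sit. Compound 4 `O=[N+]([O-])c1ccc(-c2nc3cc(C(F)(F)F)ccc3n2C2CCCCC2)cc1` is still unmeasured; it differs from compound 3 by nitro in place of acetamido on an aromatic carbon, the same change as from compound 2 to compound 1, at a place described in the same words. Since the earlier occurrence of this change was unreadable, no direction can be taken from it, and for compound 4 an estimated step of no change at the digits printed from compound 3 to compound 4 (within the scatter) in this assay is expected, close to compound 3, at roughly 15000 nM.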

Compound 4, half-maximal cytotoxic concentration: > 100000 nM
Compound 4: no number, only a limit (the forecaster's own chance of this, stated with the estimate: 15%); at least 6.6-fold (0.82 log units) between middle value and limit.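

On the cyclohexyl core, nitro in place of acetamido gives an at least 6.6-fold higher number from compound 3 to compound 4 (0.82 log units; beyond the scatter) in this assay. On these data alone, compound 4 gives > 100000 nM, which is a limit and not a number, so the full size of this step stays unknown. The same change on the core of compound 2 cannot be read, nor can the step from compound 1 to compound 4, so the result holds for the cyclohexyl core alone and does not show that the change carries across cores, because both compounds of each pair sit at one limit: the limit of > 100000 nM in this assay, at which 3 of the 4 values shown sit.

The compounds shown leave open whether an amine or a carboxylic acid in place of acetamido on the cyclohexyl core would move the number the same way. They also leave open where a longer chain on the aromatic nitrogen, in place of cyclohexyl, would fall.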